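This account rests on a few compounds, and the source may have more. Where it says the series, first, only, none or still open, it means among the compounds named here.

Compound 1 `FC(F)(F)c1ccccc1NC(=S)N/N=C/c1ccc2ccccc2n1` gives 13200 nM in a functional assay on HL-60 cells (Homo sapiens) for antiproliferative activity, read by sulforhodamine B assay, with a stated time of 72 h; on this read-out lower numbers stand for stronger inhibition and higher numbers for weaker inhibition.
Compound 2 `CN(C)C(=S)N/N=C/c1ccc2cccnc2n1` gives 560 nM in this assay.
Compound 3 `Cc1cccc(NC(=S)N/N=C/c2ccc3ccccc3n2)c1` gives only a limit, > 100000 nM, in this assay.

Among the measured compounds shown here, compound 3 stands at the limit of > 100000 nM in this assay, at which 1 of the 3 values shown sits, so no number is known for it, only that its value lies beyond that limit. Compound 4 `COc1ccc(NC(=S)N/N=C/c2ccc3ccccc3n2)cc1` differs from compound 3 in one place: 4-methoxyphenyl in place of 3-methylphenyl on an amide-type nitrogen. For the measured compounds named here, with no measured step to lean on, compound 4 is expected to remain weak in this assay, and the step from compound 3 to compound 4 is estimated as an at least 1.6-fold lower number from compound 3 to compound 4 (0.22 log units; that floor lies within the scatter), which cannot be judged against the scatter because compound 3 is a limit. The estimate for compound 4 in this assay is 60000 nM, within a range of 15000 nM to 200000 nM.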

Compound 4, half-maximal inhibitory concentration: 43800 nM
Beside the measured number, compound 4's estimate is 1.4-fold (0.14 log units) above it; low and high end bracket the measured number.
By their numbers in this assay, from the lowest: compound 2; then compound 1; then compound 4. At a limit, above all of these: compound 3.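

Among the compounds shown here, at this position, on an amide-type nitrogen whose other neighbour is the thiocarbonyl carbon, this assay now gives a first step for a change of aryl group: an at least 2.2-fold lower number from compound 3 to compound 4 (0.35 log units; beyond the scatter). Compound 4, with 4-methoxyphenyl, gives 43800 nM, a real number on this read-out. Compound 3 gives > 100000 nM, which is a limit and not a number, so the step has only a floor: the limit of > 100000 nM in this assay, at which 1 of the 4 values shown sits.

The compounds shown leave open whether the methoxy group itself or its place on the ring accounts for the step. Also open, as far as these compounds go, is how a plain phenyl or a 4-hydroxyphenyl would read on this nitrogen.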